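Aryl swap on the ring amine nitrogen: compound 4

This account rests on a few compounds, and the source may have more. Where it says the series, first, only, none or still open, it means among the compounds named here.

Measured so far:
compound 1, `Nc1scc(CN2CCN(c3ccc(Cl)cc3Cl)CC2)c1C(=O)c1ccc(Cl)cc1`, 0%
compound 2, `Nc1scc(CN2CCN(c3ccc(F)cc3Cl)CC2)c1C(=O)c1ccc(Cl)cc1`, 0%
compound 3, `Nc1scc(CN2CCN(c3ccncc3)CC2)c1C(=O)c1ccc(Cl)cc1`, 2%

All three were tested in an assay on CHO cells for displacement of a labelled ligand from adenosine receptor A3 (Homo sapiens), read by scintillation counting, with a stated time of 120 min, tested at 10 uM; a higher number here means more inhibition at the concentration tested (going by the name of the read-out), a lower number less inhibition. Compound 3 gives the highest of the three numbers, but it stands within the scatter of both neighbours: the step of a number 2 percentage points higher from compound 1 to compound 3 (within the scatter) and the step of a number 2 percentage points higher from compound 2 to compound 3 (within the scatter) are both too small to count as a change, and the step of no change at the digits printed from compound 1 to compound 2 (within the scatter) shows nothing either. Among the compounds with values here, no compound of the series so far shows measurable inhibition in this assay.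

Compound 4, `Nc1scc(CN2CCN(c3ccccc3F)CC2)c1C(=O)c1ccc(Cl)cc1`, is not yet measured. It differs from compound 3 by 2-fluorophenyl in place of pyridin-4-yl on an amine nitrogen in a ring. The two steps that bear on this change are the earlier swaps of the aryl group on the same amine nitrogen in a ring, a number 2 percentage points higher from compound 1 to compound 3 (within the scatter) and a number 2 percentage points higher from compound 2 to compound 3 (within the scatter), where a 2,4-dichlorophenyl and a 2-chloro-4-fluorophenyl were each exchanged for pyridin-4-yl without any step beyond the scatter. A third aryl group on that nitrogen is therefore expected to leave this assay essentially unchanged, with no step in either direction beyond the scatter.

For compound 4 the expected step is no change at the digits printed from compound 3 to compound 4 (within the scatter). Compound 4 is thus estimated at 2%, with a range from -6% to 12%.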

Compound 4, a percentage reported as inhibition, at one concentration (the size of the read-out at that concentration, not a potency): 0%
The estimate for compound 4 lay 2 percentage points above the measured number, within the range that was stated.
By their numbers in this assay, from the lowest: compounds 1, 2, 4 and 3 (each within the scatter of the next).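

With 2-fluorophenyl on the amine nitrogen in a ring, this assay gives a number 2 percentage points lower from compound 3 to compound 4 (within the scatter), so an aryl group of carbon only, with 0 hydrogen-bond acceptors, reads the same as pyridin-4-yl, with 1 hydrogen-bond acceptor. Set against the two dihalogenated aryl groups, the single fluorine gives no change at the digits printed from compound 2 to compound 4 (within the scatter) and no change at the digits printed from compound 1 to compound 4 (within the scatter), which extends the flat result at this position from two halogens on the phenyl ring to one, and all four compounds now lie within the scatter of one another. Nothing available explains this flat read-out, and no data on the cause of it can be cited.

On these data alone, all four compounds carry an aromatic ring on this nitrogen and share the same core, so it remains open whether a non-aromatic group such as cyclohexyl or acetyl there, or a carboxylic acid or an amine on the phenyl ring, would give any inhibition in this assay. As far as these compounds go, it also remains open whether replacing the chloro on the 4-chlorophenyl ketone of the core, for example with methoxy, would move the read-out at all.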